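Inverting one stereocentre in a large polyphenol

The source may report more compounds than this note shows. Statements on the series, on what has been measured and on what is new or still open speak of the compounds shown alone.

Compound 1 `COc1cc(O)c([C@H](/C=C/C[C@@H](O)CCc2ccc(O)cc2)c2ccc(O)cc2)c(O)c1C(=O)[C@@H]1[C@H](/C=C/c2ccc(O)cc2)C[C@H](CCc2ccc(O)cc2)O[C@H]1c1ccc(O)cc1` is one of three related polyphenols measured in a functional assay on J774.1 cells (Mus musculus) for inhibition, read by Griess assay, with a stated time of 48 h; a higher number here means a weaker inhibitor, a lower number a stronger inhibitor. In this assay compound 1 gives 36000 nM. Compound 2 `COc1cc(O)c([C@H](/C=C/C[C@@H](O)CCc2ccc(O)cc2)c2ccc(O)cc2)c(O)c1C(=O)/C=C/c1ccc(O)cc1` carries a simpler chain on the shared core and in this assay compound 2 gives 84000 nM, a number beyond the scatter of that of compound 1. Compound 3 `COc1cc(O)c([C@H](/C=C/C[C@H](CCc2ccc(O)cc2)OO)c2ccc(O)cc2)c(O)c1C(=O)/C=C/c1ccc(O)cc1` differs from compound 2 only by a hydroxy in place of hydrogen on an oxygen on a saturated carbon, and in this assay compound 3 gives 49000 nM, which lies within the scatter of the number for compound 1. Among the compounds with values here, the only step measured between two compounds differing in a single place is a 1.7-fold lower number from compound 2 to compound 3 (0.23 log units; within the scatter).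

Compound 4 `COc1cc(O)c([C@@H](/C=C/C[C@@H](O)CCc2ccc(O)cc2)c2ccc(O)cc2)c(O)c1C(=O)[C@@H]1[C@H](/C=C/c2ccc(O)cc2)C[C@H](CCc2ccc(O)cc2)O[C@H]1c1ccc(O)cc1` is now to be measured in this assay. Relative to compound 1 the change is the two compounds have the same atoms and bonds and differ only in configuration as drawn: 1 of 8 stereo elements differ; a stereocentre at a saturated chain carbon is drawn R in compound 1 and S in compound 4. Within the data shown here, no measured step concerns a change of configuration alone, so there is nothing among the measured compounds that speaks for a shift in either direction; a single inverted stereocentre can matter, yet with no evidence for it the expected step is no change at the digits printed from compound 1 to compound 4 (within the scatter), meaning none beyond the scatter. The estimate for compound 4 in this assay is therefore 36000 nM, within a range from 12000 nM to 110000 nM.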

Compound 4, half-maximal inhibitory concentration: 39000 nM
Compound 4: the middle estimate sits 1.1-fold (0.03 log units) below what was measured, and the stated range covers the measured number.
By their numbers in this assay, from the lowest: compounds 1, 4, 3 and 2 (each within the scatter of the next, the first and the last beyond it).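

In this assay, within the data shown here, inverting the stereocentre at a saturated chain carbon from R to S gives a 1.1-fold higher number from compound 1 to compound 4 (0.03 log units; within the scatter) and so provides the first measured step that concerns configuration alone. Among these compounds, the earlier compounds could not speak to the handedness of this carbon, since their only single-place step was a change of hydroxy on an oxygen. In this pair, the drawn configuration at this position moves the number by no more than repeated measurements would, and the step can be read as belonging to this one carbon alone, for a simple reason: the fact that compounds 1 and 4 differ only in the configuration as drawn

Whether the same inversion would also leave the number within the scatter on the simpler structure of compound 2 stays open, as does the contribution of each of the other stereo elements of compound 1, none of which is inverted in any compound shown. Also open, from the compounds shown here alone, is how the number would respond if a group of another kind, such as an amine or a carboxylic acid, stood in place of the hydroxy on the chain of compound 1, or if that chain were longer.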